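The source may report more compounds than this note shows. Statements on the series, on what has been measured and on what is new or still open speak of the compounds shown alone.

In a functional assay on KB cells (Homo sapiens) for cytotoxicity (on this read-out higher numbers stand for lower toxicity in this test and lower numbers for higher toxicity in this test), compound 1 (`NNc1nc(N)nc2c1ncn2[C@@H]1O[C@H](CO)[C@@H](O)[C@H]1O`) gives 1360000 nM as its result. Compound 2 (`CO/N=c1/[nH]c(N)nc2c1ncn2[C@@H]1O[C@H](CO)[C@@H](O)[C@H]1O`) gives 784000 nM in this assay as well. Going by the values given here, these two numbers lie within the usual scatter of each other, so compound 1 stands level with the only other compound that has a number. Compound 3 (`CO/N=c1/[nH]c(N)nc2[nH]cnc12`) has no number: "not determined" (no result reported).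

Compound 4 (`CN(N)c1nc(N)nc2c1ncn2[C@@H]1O[C@H](CO)[C@@H](O)[C@H]1O`) has not yet been measured. It differs from compound 1 by a single change, methyl in place of hydrogen on a nitrogen on an aromatic ring.

Among the compounds with values here, no measured pair shows this change on its own, so the expectation has little to rest on. With compound 1 at 1360000 nM and compound 2 at 784000 nM in the same range, no large step is expected. The estimated step of a 1.5-fold lower number from compound 1 to compound 4 (0.18 log units; within the scatter) is a slight drift towards lower numbers that stays within the scatter. For compound 4 the expected value is 900000 nM, with an estimated range from 300000 nM to 2000000 nM.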

Compound 4, half-maximal cytotoxic concentration: 1480000 nM
Compound 4: the middle estimate sits 1.6-fold (0.22 log units) below what was measured; measured number inside the range.
By their numbers in this assay, from the lowest: compounds 2, 1 and 4 (each within the scatter of the next).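

Going by these compounds alone, the pair of compound 1 and compound 4 is the first to show methyl in place of hydrogen on a nitrogen on an aromatic ring with nothing else altered, and it gives a 1.1-fold higher number from compound 1 to compound 4 (0.04 log units; within the scatter). So in this assay this position takes one methyl without any step that can be told apart from ordinary repeat-to-repeat variation, which the earlier compounds, differing from one another in more than one place, could not show. Nothing in the available information explains this result.

On these data alone, whether the same holds for a larger group on this nitrogen, such as an ethyl, a longer chain or an acetyl, stays open. This is also a single pair in a single assay, so it cannot say whether the methyl would behave the same way on another core.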